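The source may report more compounds than this note shows. Statements on the series, on what has been measured and on what is new or still open speak of the compounds shown alone.

Measured so far in a functional assay on VCaP cells (Homo sapiens) for antiproliferative activity, read by propidium iodide staining, with a stated time of 96 h; a lower number here means a stronger inhibitor, a higher number a weaker inhibitor:

Compound 1, `CC(O)(COc1cccc(C(F)(F)F)c1)C(=O)Nc1ccc(S(F)(F)(F)(F)F)cc1`: compound 1 gives 24700 nM
Compound 2, `CC(O)(COc1cc(C(F)(F)F)cc(C(F)(F)F)c1)C(=O)Nc1ccc(S(F)(F)(F)(F)F)cc1`: compound 2 gives 2600 nM
Compound 3, `CC(O)(COc1ccc(C#N)cc1)C(=O)Nc1cccc(S(F)(F)(F)(F)F)c1`: compound 3 gives 26600 nM

Compound 1 and compound 2 share one core, and compound 3 carries a second one; the difference between the two cores is not broken down here. Compound 1 and compound 3 give numbers that lie within the usual scatter of each other, so nothing separates them. Compound 2 gives a lower number than either.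

Within the first core, one change has been measured: trifluoromethyl in place of hydrogen on an aromatic carbon This gave a 9.5-fold lower number from compound 1 to compound 2 (0.98 log units; beyond the scatter). The same kind of change is now to be made on the second core, leading from compound 3 to compound 4, `CC(O)(COc1ccc(C#N)cc1C(F)(F)F)C(=O)Nc1cccc(S(F)(F)(F)(F)F)c1`: trifluoromethyl in place of hydrogen on an aromatic carbon The surroundings are not the same word for word: in the measured case the entering group sits meta to a large group and meta to a trifluoromethyl group, while in compound 4 it sits ortho to a large group and meta to a cyano group. It is therefore the same kind of change, not the same change.

Going by the values given here, only one example supports a transfer, and its surroundings differ, so a smaller step than the measured one seems the safer expectation. The step from compound 3 to compound 4 is expected to be a 3.8-fold lower number from compound 3 to compound 4 (0.58 log units; beyond the scatter), resting on a 9.5-fold lower number from compound 1 to compound 2 (0.98 log units; beyond the scatter) discounted for the changed surroundings. Compound 4 is thus estimated to give about 7000 nM in this assay, with a likely range from 2500 nM to 20000 nM.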

Compound 4, half-maximal inhibitory concentration: 30600 nM
Estimate against measurement, compound 4: 4.4-fold (0.64 log units) below; measured number above the stated range.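

In this assay, putting trifluoromethyl in place of hydrogen on an aromatic carbon of the second core gave a 1.2-fold higher number from compound 3 to compound 4 (0.06 log units; within the scatter), so on this core the change produced no difference that can be told from the scatter of repeated measurements. Set beside the earlier case, the size of the step clearly depended on where the change was made, and the gain seen on the first core did not carry over to the second: the same change on two cores in this assay, a 9.5-fold lower number (0.98 log units; beyond the scatter) from compound 1 to compound 2 and a 1.2-fold higher number (0.06 log units; within the scatter) from compound 3 to compound 4, 11-fold (1.04 log units) apart, beyond the scatter of two such steps

This does not show that the core alone decides the outcome, since the surroundings of the entering group also differ between the two cases: in compound 4 it sits ortho to a large group and meta to a cyano group, unlike in compound 2, and two examples cannot separate these influences or support a general rule.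

The compounds shown leave open whether trifluoromethyl would lower the number on the second core if it stood on another carbon of that ring. They also leave open whether a chlorine atom, a methyl group or an amine in the place it occupies in compound 4 would give a different number from compound 3.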